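A few compounds are considered here, and "the series" means these few. Any claim that something is new, unique, unknown or untested is made for them only; others in the source may bear on it.

The measured compounds, all tested in a functional assay on A549 cells (Homo sapiens) for antiproliferative activity, read by MTT assay, with a stated time of 24 h; a higher number here means a weaker inhibitor, a lower number a stronger inhibitor:

Compound 1 `O=c1[nH]cc(S(=O)(=O)Nc2ccccc2-c2cn(-c3ccccc3)nn2)c(=O)[nH]1` gives 6790 nM in this assay.
Compound 2 `O=c1[nH]cc(S(=O)(=O)Nc2ccccc2-c2cn(-c3ccc(F)cc3)nn2)c(=O)[nH]1` gives 6390 nM in this assay.
Compound 3 `O=c1[nH]cc(S(=O)(=O)Nc2cccc(-c3cn(-c4ccccc4)nn3)c2)c(=O)[nH]1` gives 12700 nM in this assay.

Compound 3 has the highest of the three numbers, but its gaps to compound 1 and to compound 2 both lie within the usual scatter of repeated measurements, so the three compounds cannot be told apart on these data.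

Compound 4 `Cc1ccccc1-n1cc(-c2cccc(NS(=O)(=O)c3c[nH]c(=O)[nH]c3=O)c2)nn1` differs from compound 3 in one place: methyl in place of hydrogen on an aromatic carbon. The methyl sits on an aromatic carbon of a six-membered aromatic ring of carbon only, ortho to a large group; seen one bond further out, a phenyl becomes a 2-methylphenyl.

Among the compounds with values here, only one measured step bears on this change: the same ring carries fluoro in place of hydrogen going from compound 1 to compound 2, and that step was a 1.1-fold lower number from compound 1 to compound 2 (0.03 log units; within the scatter), within the scatter. A small substituent on this ring therefore left the number essentially unchanged once. On that single precedent, the expected step of a 1.1-fold lower number from compound 3 to compound 4 (0.02 log units; within the scatter) is none beyond the scatter.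

Compound 4 is thus estimated at 12000 nM in this assay, with a range from 5500 nM to 26000 nM.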

Compound 4, half-maximal inhibitory concentration: 5470 nM
Compound 4: the middle estimate sits 2.2-fold (0.34 log units) above what was measured; measured number below the stated range.
By their numbers in this assay, from the lowest: compounds 4, 2, 1 and 3 (each within the scatter of the next, the first and the last beyond it).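

On the phenyl ring that becomes a 2-methylphenyl, a small substituent can move the number: methyl in place of hydrogen on an aromatic carbon, ortho to a large group, gives in this assay a 2.3-fold lower number from compound 3 to compound 4 (0.37 log units; beyond the scatter) and so is a modest step, but the first shown here to lie beyond the scatter. Within the data shown here, the only earlier change on this ring, a 1.1-fold lower number from compound 1 to compound 2 (0.03 log units; within the scatter), did not do so, which means this ring does not tolerate every small substituent without a measurable shift; still, those two steps differ both in the entering group and in the compound that carries it, so a single example of each cannot separate these two differences. Nothing measured here gives a reason for the lower number of compound 4.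

An ethyl, a methoxy, an amine or a carboxylic acid on the same carbon could show whether this step is particular to methyl or extends to other groups. Methyl on the matching carbon of compound 1 could show whether the step carries over to that compound.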